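The source may hold more compounds than are shown below. What is called first, only, known or untested is meant among the compounds shown, and "the series" means these compounds.

Working notes on the series. Compound 1 `COc1cc(/C=C/C(C)=O)ccc1OCc1cn(-c2c(Cl)cccc2Cl)nn1` stands at the lower of the two numbers measured in a functional assay on HCT-116 cells (Homo sapiens) for antiproliferative activity, read by MTT assay, with a stated time of 48 h (on this read-out higher numbers stand for weaker inhibition and lower numbers for stronger inhibition), giving 2000 nM there. Compound 2 `COc1cc(/C=C/C(C)=O)ccc1OCc1cn(-c2ccc(-c3ccccc3)cc2)nn1` gives 65300 nM in this assay, a gap beyond the scatter, so compound 1 is the stronger of the two measured compounds. Among the measured compounds shown here, no pair of measured compounds differs in a single place, so no single-change step is available to guide the next move.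

Compound 3 `COc1cc(/C=C/C(C)=O)ccc1OCc1cn(-c2ccccc2O)nn1` is the unmeasured member; it differs from compound 1 by 2-hydroxyphenyl in place of 2,6-dichlorophenyl on an aromatic nitrogen.

On the two numbers available, a change at this position can cost a great deal, as the gap between compound 1 and compound 2 shows. For compound 3 a moderate loss relative to compound 1 is expected, a step of a 2.5-fold higher number from compound 1 to compound 3 (0.40 log units; beyond the scatter) in this assay. Compound 3 is accordingly estimated at 5000 nM, with a range from 1200 nM to 20000 nM.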

Compound 3, half-maximal inhibitory concentration: 76400 nM
Beside the measured number, compound 3's estimate is 15-fold (1.18 log units) below it, and the stated range ends below it.
By their numbers in this assay, from the lowest: compound 1; then compounds 2 and 3 (each within the scatter of the next).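

In this assay the series now has its first single-change step, and it is large: a 38-fold higher number from compound 1 to compound 3 (1.58 log units; beyond the scatter), with 2-hydroxyphenyl in place of 2,6-dichlorophenyl on the aromatic nitrogen. The six-membered aromatic ring of carbon stays and only its substituents change, so this position does not tolerate every exchange of substituents on that ring, even with the ring itself kept. No measurement at hand accounts for the size of this step.

From the compounds shown here alone, this single step removes both chlorines and adds the hydroxyl together, so it remains open whether the loss follows the chlorines leaving or the hydroxyl entering. A 2-chlorophenyl, 2-methoxyphenyl or 2-aminophenyl group at the same place would separate these two changes.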